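A few compounds are considered here, and "the series" means these few. Any claim that something is new, unique, unknown or untested is made for them only; others in the source may bear on it.

Measured so far:
Compound 1, `O=C(O)Cc1sc(C(c2ccc(F)cc2)c2ccc(F)cc2)nc1-c1ccc(Cl)cc1`, in an in vitro functional assay on HEK285-7 cells for antagonist activity at prostaglandin D2 receptor 2 (Homo sapiens), read by BRET and beta-arrestin recruitment (on this read-out higher numbers stand for weaker inhibition and lower numbers for stronger inhibition), gives 180 nM.
Compound 2, `Cc1cc(-c2nc(C(c3ccc(F)cc3)c3ccc(F)cc3)sc2CC(=O)O)ccn1`, in this assay gives 53 nM.

Among the compounds with values here, compound 2 has the lower of the two numbers, and the only measured step, a 3.4-fold lower number from compound 1 to compound 2 (0.53 log units; beyond the scatter), sets it apart from compound 1 beyond the scatter. Compound 3, `Cc1cc(-c2nc(C(c3ccc(F)cc3)c3ccc(F)cc3)sc2CC(=O)O)cnc1N`, is not yet measured. It differs from compound 2 in one place: 6-amino-5-methylpyridin-3-yl in place of 2-methylpyridin-4-yl on an aromatic carbon. Within the data shown here, that one step shows a modest shift when the aromatic group at this position is exchanged, but no measured step matches this particular exchange. The expected step is therefore small, a 1.1-fold higher number from compound 2 to compound 3 (0.05 log units; within the scatter). In this assay compound 3 is estimated at 60 nM, within 20 nM to 200 nM.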

Compound 3, half-maximal inhibitory concentration: > 100000 nM
Compound 3 gave a limit, no number; the forecaster's own chance of this, stated with the estimate: 5%; middle value at least 1600-fold (3.22 log units) away from the limit.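

In this assay compound 3 gives > 100000 nM, which is a limit of the assay and not a number. The earlier exchange at this aromatic carbon brought only a modest shift, but this one is far larger: an at least 1800-fold higher number from compound 2 to compound 3 (3.27 log units; beyond the scatter), and an at least 550-fold higher number from compound 1 to compound 3 (2.74 log units; beyond the scatter). Exchanging one six-membered aromatic ring for another here can therefore do much more than adjust the number.

The compounds shown do not separate the part played by the amino group from that of the methyl group on the entering ring. Going by these compounds, it also remains open whether a methoxy group in place of the amino group would give the same loss.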